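This account rests on a few compounds, and the source may have more. Where it says the series, first, only, none or still open, it means among the compounds named here.

Compound 1 `CC(C)[C@@H](NC(=O)OC(C)(C)C)C(=O)Nc1ccc2ncnc(Nc3cccc(Br)c3)c2c1` is tested in a functional assay on HepG2 cells (Homo sapiens) for antiproliferative activity, read by sulforhodamine B assay, with a stated time of 72 h (a lower number here means a stronger inhibitor, a higher number a weaker inhibitor), where it gives > 50000 nM. As far as these compounds go, that is a limit of the assay and not a number, so the true position of compound 1 is unknown. Compound 2 `CC(C)[C@@H](NC(=O)OC(C)(C)C)C(=O)Nc1ccc2ncnc(Nc3cccc(C(F)(F)F)c3)c2c1`, with trifluoromethyl in place of bromo on an aromatic carbon, gives a real number of 4300 nM. This measured step is an at least 11-fold lower number from compound 1 to compound 2 (1.06 log units; beyond the scatter).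

Compound 3 `CC(C)(C)OC(=O)NCC(=O)Nc1ccc2ncnc(Nc3cccc(Br)c3)c2c1` keeps the bromo of compound 1 and changes elsewhere: hydrogen in place of isopropyl on a saturated chain carbon bound to an amide-type nitrogen and a carbonyl carbon. Within the data shown here, no measured step touches this carbon. Among the measured compounds shown here, the large step to compound 2 shows only that one small swap can matter, and it says nothing about direction here. The bromo that compound 3 retains points to a weak result in this assay, so no clear shift is expected, and another limit is quite possible. The expected outcome is an at least 1.2-fold lower number from compound 1 to compound 3 (0.09 log units; that floor lies within the scatter). For compound 3, the estimated value is 40000 nM, with an expected range of 8000 nM to 100000 nM.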

Compound 3, half-maximal inhibitory concentration: 8300 nM
Estimate against measurement, compound 3: 4.8-fold (0.68 log units) above; low and high end bracket the measured number.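

In this assay, this saturated chain carbon clearly matters: with the bromo kept in place, hydrogen in place of isopropyl gives an at least 6.0-fold lower number from compound 1 to compound 3 (0.77 log units; beyond the scatter). Until now, only the swap on the aromatic carbon had moved the number; this step shows that a second place in the molecule can do so too, and that a bromo compound in this series can give a real number. Compound 1 stands at a limit and not at a number, so the true size of the step remains unknown and only its lower bound can be read: the limit of > 50000 nM in this assay, at which 1 of the 3 values shown sits.

Only isopropyl and hydrogen are seen on this carbon, which leaves open how a methyl, a longer chain, or a chain carrying an amine or a carboxylic acid would behave there. As far as these compounds go, it is also open whether hydrogen on this carbon and trifluoromethyl on the aromatic carbon would work together in one compound, or whether the effect of each depends on the other.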